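Adding a Hydroxy Group to Compound 2

The source may hold more compounds than are shown below. What is called first, only, known or untested is meant among the compounds shown, and "the series" means these compounds.

Compound 1 (`CC(C)[C@H](NC(=O)c1ccc(Br)cc1)C(=O)N1C[C@H](O)C[C@H]1C(=O)N[C@@H](CCCNC(=N)N)C(=O)CF`): 70 nM
Compound 2 (`N=C(N)NCCC[C@H](NC(=O)[C@@H]1CCCN1C(=O)[C@@H](NC(=O)c1ccc(Br)cc1)C1CCCCC1)C(=O)CF`): 130 nM

In a functional assay on OCI-Ly3 cells (Homo sapiens) for inhibition, read by CellTiter-Glo, with stated times of 48 h and 96 h (a lower number here means a stronger inhibitor of growth, a higher number a weaker inhibitor of growth), compound 2 stands within the usual scatter of compound 1, so these two values give no ranking. Compound 3 (`N=C(N)NCCC[C@H](NC(=O)[C@@H]1C[C@@H](O)CN1C(=O)[C@@H](NC(=O)c1ccc(Br)cc1)C1CCCCC1)C(=O)CF`) is built on compound 2, with hydroxy in place of hydrogen on a saturated ring carbon. Among the measured compounds shown here, no measured pair shows this change alone. Compound 1 also carries a hydroxy group and gives 70 nM but differs from compound 3 elsewhere as well, so it offers only a loose guide. No step beyond the scatter is therefore expected in this assay and no firm direction can be given. The estimate corresponds to an expected 1.3-fold lower number from compound 2 to compound 3 (0.11 log units; within the scatter) within the scatter. Compound 3 is expected at 100 nM with an estimated range from 40 nM to 250 nM in this growth measurement.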

Compound 3, concentration for 50% growth inhibition: 60 nM
The estimate for compound 3 lay 1.7-fold (0.22 log units) above the measured number; low and high end bracket the measured number.
By their numbers in this assay, from the lowest: compounds 3, 1 and 2 (each within the scatter of the next, the first and the last beyond it).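

In this assay, among the compounds shown here, hydroxy in place of hydrogen on this saturated ring carbon, two ring bonds from the ring nitrogen, gives the first step that can be read for this change alone (a 2.2-fold lower number from compound 2 to compound 3 (0.34 log units; beyond the scatter)), and that step is modest. With the hydroxy group in place, cyclohexyl in place of isopropyl gives no separation of the two compounds (a 1.2-fold lower number from compound 1 to compound 3 (0.07 log units; within the scatter)). Nothing available here explains the step from hydrogen to hydroxy. Going by these compounds, it remains open whether an amine, a methoxy group or a fluorine atom in place of the hydroxy group would give a step of similar size. The compounds shown also leave open what the hydroxy group does when isopropyl stands in place of cyclohexyl, and whether its step carries over to any other measure of activity.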